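This account rests on a few compounds, and the source may have more. Where it says the series, first, only, none or still open, it means among the compounds named here.

Measured in a functional assay on MDA-MB-231 cells (Homo sapiens) for cytotoxicity, read by MTT assay, with a stated time of 48 h (on this read-out lower numbers stand for stronger inhibition and higher numbers for weaker inhibition), with all three values being limits of the assay:
- compound 1 `NC(=O)CC[C@H](NS(=O)(=O)c1ccc([N+](=O)[O-])cc1)C(=O)O` gives > 500000 nM as a limit
- compound 2 `CC(C)NC(=O)CC[C@H](NS(=O)(=O)c1ccc([N+](=O)[O-])cc1)C(=O)O` gives > 500000 nM as a limit
- compound 3 `CCCCNC(=O)CC[C@H](NS(=O)(=O)c1ccc([N+](=O)[O-])cc1)C(=O)O` gives > 500000 nM as a limit

Compound 2 stands only at a limit, with > 500000 nM as its entry and no number behind it. The whole set shows the same picture, namely (the limit of > 500000 nM in this assay, at which 3 of the 3 values shown sit).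

Compound 4 `O=C(CC[C@H](NS(=O)(=O)c1ccc([N+](=O)[O-])cc1)C(=O)O)NCc1ccccc1` carries benzyl in place of isopropyl on an amide-type nitrogen, the counted difference being (benzyl in place of isopropyl on an amide-type nitrogen).

Within the data shown here, three measured steps bear on this change, all made on that same nitrogen: a step that the two limits leave unreadable from compound 1 to compound 2, a step that the two limits leave unreadable from compound 1 to compound 3 and a step that the two limits leave unreadable from compound 2 to compound 3. None of them has a readable size, so they set no direction and give no trend to extend.

Among the measured compounds shown here, with the limit of > 500000 nM in this assay, at which 3 of the 3 values shown sit, as the only guide, no readable change is expected in this assay, though a weak number on the stronger side remains possible. The expected outcome is a number no higher from compound 2 to compound 4 (the limit leaves the size open) and this estimate is loose. Compound 4 is estimated at 500000 nM with an expected range of 200000 nM to 1000000 nM and is most likely to be reported as a limit again.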

Compound 4, half-maximal inhibitory concentration: 175000 nM
For compound 4 the middle estimate is 2.9-fold (0.46 log units) above the measured one; the whole stated range lies above it.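

In this assay, benzyl is the only group shown on the amide-type nitrogen that gives a number rather than a limit, with an at least 2.8-fold lower number from compound 2 to compound 4 (0.45 log units; beyond the scatter) for benzyl in place of isopropyl and an at least 2.8-fold lower number from compound 1 to compound 4 (0.45 log units; beyond the scatter) for benzyl in place of hydrogen. Phenyl in place of propyl on the saturated chain carbon bound to that nitrogen gives an at least 2.8-fold lower number from compound 3 to compound 4 (0.45 log units; beyond the scatter), so this position can respond to a change in this assay, and the response appears here only with the group carrying the six-membered aromatic ring. The steps among compounds 1, 2 and 3 cannot be read, and each of those compounds is held at a limit of the assay: the limit of > 500000 nM in this assay, at which 3 of the 4 values shown sit.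

As far as these compounds go, all three new steps are bounded on one side only, so their true sizes remain open, and a single compound cannot show whether the aromatic ring itself matters or only the larger group. Cyclohexylmethyl on the same nitrogen would test the need for the aromatic ring, while phenyl or 2-phenylethyl would test the length of the chain linking that ring to the nitrogen.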